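The compounds below may be only part of what the source reports. "The series", "measured", "known", "first", "only" and "open" are said of these compounds alone.

Compound 1 `O=C(Nc1cccc(-c2oc3cc(-c4ccc(F)cc4)ccc3c(=O)c2O)c1)c1ccc(F)cc1F`, compound 2 `Cc1cccc(C(=O)Nc2cccc(-c3oc4cc(-c5ccc(F)cc5)ccc4c(=O)c3O)c2)c1` and compound 3 `CCc1ccc(C(=O)Nc2cccc(-c3oc4cc(-c5ccc(F)cc5)ccc4c(=O)c3O)c2)cc1` share one core and differ only in the aryl group attached to the amide carbonyl. In a functional assay on MCF7 cells (Homo sapiens) for antiproliferative activity, read by CCK-8 assay, with a stated time of 72 h (a higher number here means a weaker inhibitor, a lower number a stronger inhibitor), compound 1 gives 13500 nM, compound 2 gives 7850 nM, and compound 3 gives 22800 nM. Compound 3 thus has the highest of the three numbers: a 1.7-fold higher number from compound 1 to compound 3 (0.23 log units; within the scatter), while a 2.9-fold higher number from compound 2 to compound 3 (0.46 log units; beyond the scatter). Compound 4 `COc1ccc(C(=O)Nc2cccc(-c3oc4cc(-c5ccc(F)cc5)ccc4c(=O)c3O)c2)c(F)c1` differs from compound 3 in one place: 2-fluoro-4-methoxyphenyl in place of 4-ethylphenyl on a carbonyl carbon. The measured steps that bear on this exchange are those among the three aryl groups already in hand, a 1.7-fold lower number from compound 1 to compound 2 (0.24 log units; within the scatter) and the two just named; none of them moves the number far, and compound 1, whose aryl group also carries fluorine, lies within the scatter of compound 3. The author therefore expects a 1.8-fold lower number from compound 3 to compound 4 (0.24 log units; within the scatter) for compound 4, a small shift toward a lower number at most. The estimate for compound 4 in this assay is 13000 nM, with a range from 5000 nM to 32000 nM.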

Compound 4, half-maximal inhibitory concentration: 20000 nM
For compound 4 the middle estimate is 1.5-fold (0.19 log units) below the measured one; the range from low to high includes it.
By their numbers in this assay, from the lowest: compounds 2, 1, 4 and 3 (each within the scatter of the next, the first and the last beyond it).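

In this assay, 2-fluoro-4-methoxyphenyl in place of 4-ethylphenyl on the carbonyl carbon gives a 1.1-fold lower number from compound 3 to compound 4 (0.06 log units; within the scatter), so this exchange, which brings in a hydrogen-bond acceptor, does not separate the two compounds. The narrowest exchange at this position, methoxy in place of fluoro on an aromatic carbon, gives a 1.5-fold higher number from compound 1 to compound 4 (0.17 log units; within the scatter), while a 2.5-fold higher number from compound 2 to compound 4 (0.41 log units; beyond the scatter) makes compound 4 the second compound, after compound 3, to stand beyond the scatter from compound 2, although compound 1 lies within the scatter of all three. Nothing given here explains these numbers.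

From the compounds shown here alone, it remains open whether a morpholine or a carboxylic acid on this aryl ring would move the number further. A longer alkyl chain in place of the ethyl of compound 3 is equally untested by these compounds.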